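The source may report more compounds than this note shows. Statements on the series, on what has been measured and on what is new or still open speak of the compounds shown alone.

In an ADME assay on MT2 cells (Homo sapiens) for cytotoxicity, read by XTT assay, with a stated time of 4 days (on this read-out higher numbers stand for lower toxicity in this test and lower numbers for higher toxicity in this test), compound 2 `Cc1nc(C(NC(=O)C(=O)Nc2ccc(Cl)cc2)C2CCNCC2)sc1CCO` is recorded at > 78500 nM, which is a limit of the assay and not a number. Compound 1 `Cc1nc(C(NC(=O)C(=O)Nc2ccc(Cl)cc2)C2CCNCC2)sc1CO` is recorded at > 81000 nM, which is also a limit. Going by the values given here, compound 3 `Cc1nc(C(NC(=O)C(=O)Nc2ccc(Cl)c(F)c2)C2CCCCN2)sc1CO` gives 77800 nM, the one true number among the three. Compound 2 therefore has no exact place on the scale, and its standing is known only through its limit.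

The next compound, compound 4 `CC(=O)N1CCCCC1C(NC(=O)C(=O)Nc1ccc(Cl)cc1)c1nc(C)c(CCO)s1`, carries 1-acetylpiperidin-2-yl in place of piperidin-4-yl on a saturated chain carbon bound to an amide-type nitrogen and an aromatic carbon.

Among the compounds with values here, only one measured step links these compounds, a step that the two limits leave unreadable from compound 1 to compound 2. It concerns a different part of the structure and gives no size to carry over to this change. With no readable step as a guide, no change beyond the scatter is expected in this assay, and no direction can be favoured. The expected level rests on compound 3 at 77800 nM. A further report of a limit would be no surprise.

The expected move is an at least 1.0-fold lower number from compound 2 to compound 4 (0.03 log units; that floor lies within the scatter). For compound 4 the estimated value is 72000 nM, with an expected range from 35000 nM to 100000 nM.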

Compound 4, half-maximal cytotoxic concentration: > 84000 nM
Compound 4 gave a limit, no number; the forecaster's own chance of this, stated with the estimate: 60%; middle value at least 1.1-fold (0.06 log units) away from the limit.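

In this assay compound 4 is recorded at > 84000 nM, which is a limit of the assay and not a number. Compound 2 also stands at a limit, so no step can be read between compound 2 and compound 4. The compounds shown leave open how far 1-acetylpiperidin-2-yl in place of piperidin-4-yl moves the half-maximal cytotoxic concentration.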